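Working notes: vinyl in place of hydrogen on compound 3

The source may report more compounds than this note shows. Statements on the series, on what has been measured and on what is new or still open speak of the compounds shown alone.

- Compound 1 `COc1cc(-c2ccnc3cc(-c4cn(CO)c5ccccc45)nn23)cc(OC)c1OC`: 128 nM
- Compound 2 `COc1cc(-c2ccnc3cc(-c4ccc(Cl)cc4)nn23)cc(OC)c1OC`: 3340 nM
- Compound 3 `COc1cc(-c2ccnc3cc(-c4ccccc4)nn23)cc(OC)c1OC`: 3880 nM

In a functional assay on HCT-116 cells (Homo sapiens) for inhibition, read by CCK-8 assay, with a stated time of 48 h (on this read-out higher numbers stand for weaker inhibition and lower numbers for stronger inhibition), compound 3 gives 3880 nM, within the scatter of compound 2 and well beyond it from compound 1. Compound 4 `C=Cc1ccc(-c2cc3nccc(-c4cc(OC)c(OC)c(OC)c4)n3n2)cc1` carries vinyl in place of hydrogen on an aromatic carbon, para to a large group: vinyl in place of hydrogen on an aromatic carbon. Within the data shown here, the one measured step on this ring, a 1.2-fold higher number from compound 2 to compound 3 (0.07 log units; within the scatter), exchanges chloro for hydrogen and stays within the scatter. Vinyl itself is unmeasured, so no step beyond the scatter is expected in this assay. The expected step is a 1.2-fold lower number from compound 3 to compound 4 (0.08 log units; within the scatter). Compound 4 is expected at 3200 nM, with an estimated range of 1200 nM to 7500 nM.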

Compound 4, half-maximal inhibitory concentration: 1060 nM
Beside the measured number, compound 4's estimate is 3.0-fold (0.48 log units) above it; the measured number lies below the stated range.
By their numbers in this assay, from the lowest: compound 1; then compound 4; then compounds 2 and 3 (each within the scatter of the next).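

In this assay, vinyl in place of hydrogen gives a 3.7-fold lower number from compound 3 to compound 4 (0.56 log units; beyond the scatter), and vinyl in place of chloro gives a 3.2-fold lower number from compound 2 to compound 4 (0.50 log units; beyond the scatter). This carbon, para to a large group, therefore responds to substitution, which the exchange of chloro for hydrogen alone, a 1.2-fold higher number from compound 2 to compound 3 (0.07 log units; within the scatter), did not show. Nothing measured here explains why vinyl differs from chloro and hydrogen at this position.

Whether the gain is particular to vinyl remains open, since ethyl, an ethynyl group, an amine and a carboxylic acid on the same carbon do not appear among these compounds.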